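Fluoro on the fused ring of compound 2

A few compounds are considered here, and "the series" means these few. Any claim that something is new, unique, unknown or untested is made for them only; others in the source may bear on it.

Measured compounds:
compound 1 `COc1cc2c(Oc3ccc(NC(=O)c4cc(-c5cccc(Cl)c5)nc5ccccc45)cc3F)ccnc2cc1OCCCN1CCCCC1`: 150 nM
compound 2 `COc1cc2c(Oc3ccc(NC(=O)c4cc(-c5cccc(Cl)c5)nc5ccccc45)cc3F)ccnc2cc1OCCCN1CCC(C)CC1`: 580 nM
compound 3 `COc1cc2c(Oc3ccc(NC(=O)c4cc(-c5ccccc5)nc5ccccc45)cc3F)ccnc2cc1OCCCN1CCC(C)CC1`: 920 nM

In a functional assay on U-87MG ATCC cells (Homo sapiens) for cytotoxicity, read by MTT assay, with a stated time of 72 h (on this read-out higher numbers stand for weaker inhibition and lower numbers for stronger inhibition), compound 2 gives 580 nM, the second highest of the three numbers. Its nearest neighbour is compound 3, as the step of a 1.6-fold higher number from compound 2 to compound 3 (0.20 log units; within the scatter) lies within the scatter; its furthest is compound 1, as the step of a 3.9-fold higher number from compound 1 to compound 2 (0.59 log units; beyond the scatter) lies beyond it.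

Compound 4 `COc1cc2c(Oc3ccc(NC(=O)c4cc(-c5cccc(Cl)c5)nc5ccc(F)cc45)cc3F)ccnc2cc1OCCCN1CCC(C)CC1` is not yet measured. It differs from compound 2 by fluoro in place of hydrogen on an aromatic carbon. Within the data shown here, no measured step touches this fused ring: the step from compound 1 to compound 2 concerns a saturated ring, and the step from compound 2 to compound 3 concerns the pendant aryl ring, where removing chloro changed the number only within the scatter. The data give no ground for a step beyond the scatter in this assay. Compound 4 is therefore expected to give about 500 nM (estimated range 200 nM to 1500 nM), a step of a 1.2-fold lower number from compound 2 to compound 4 (0.06 log units; within the scatter) that is expected to stay within the scatter.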

Compound 4, half-maximal inhibitory concentration: 110 nM
The estimate for compound 4 lay 4.5-fold (0.66 log units) above the measured number, outside the stated range (below it).
By their numbers in this assay, from the lowest: compounds 4 and 1 (each within the scatter of the next); then compounds 2 and 3 (each within the scatter of the next).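

In this assay, among these compounds, the carbon of the fused ring system that carries the new fluoro proves sensitive: fluoro in place of hydrogen there gives a 5.3-fold lower number from compound 2 to compound 4 (0.72 log units; beyond the scatter) and so moves the number beyond the scatter, which no earlier compound could show, since none changed this ring. The earlier change on an aromatic carbon, a 1.6-fold higher number from compound 2 to compound 3 (0.20 log units; within the scatter) on the pendant aryl ring, stayed within the scatter, so a change of one substituent on an aromatic carbon does not count the same at every place in this series. No available evidence accounts for the stronger inhibition seen with fluoro at this position.

As far as these compounds go, whether chloro, methoxy or a nitrile on this aromatic carbon would act as fluoro does remains open. Equally open, from the compounds shown here alone, is whether fluoro here would give a step of similar size on compound 1 or compound 3.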